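A few compounds are considered here, and "the series" means these few. Any claim that something is new, unique, unknown or untested is made for them only; others in the source may bear on it.

Measured compounds:
- compound 1 `Cc1cccc(CN2CCC=C(CCC(=O)NO)C2=O)c1`: 8120 nM
- compound 2 `O=C(CCC1=CCCN(Cc2ccc3ccccc3c2)C1=O)NO`: "not determined" (no result reported)

The series is small. In a functional assay on MDA-MB-231 cells (Homo sapiens) for inhibition, read by sulforhodamine B assay (a higher number here means a weaker inhibitor of growth, a lower number a stronger inhibitor of growth), compound 1 gives 8120 nM, and this is the only number shown. Compound 2 has no result in this assay, so compound 1 stands alone and cannot be placed against any other value; no comparison between two measured compounds exists here.

The next compound is compound 3 `O=C(CCC1=CCCN(Cc2ccc(Br)cc2)C1=O)NO`. It differs from compound 1 in one place: 4-bromophenyl in place of 3-methylphenyl on a saturated chain carbon bound to an amide-type nitrogen in a ring. The shared core with its hydroxamic acid chain is unchanged; only the group on the saturated chain carbon bound to the amide-type nitrogen in the ring is exchanged, a 4-bromophenyl in place of a 3-methylphenyl.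

Among the measured compounds shown here, no step between measured compounds is available to calibrate what such a swap does in this assay. For the measured compounds named here, with a single point and no comparable pair, the expectation is a step from compound 1 to compound 3 of no more than the usual scatter, with a wide range to cover either direction. The step expected is a 1.2-fold lower number from compound 1 to compound 3 (0.10 log units; within the scatter). Compound 3 is accordingly estimated at 6500 nM, with a range from 2500 nM to 17000 nM.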

Compound 3, concentration for 50% growth inhibition: 1630 nM
Beside the measured number, compound 3's estimate is 4.0-fold (0.60 log units) above it, outside the stated range (below it).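

In this assay the group on a saturated chain carbon bound to an amide-type nitrogen in a ring clearly affects the read-out: 4-bromophenyl in place of 3-methylphenyl gives a 5.0-fold lower number from compound 1 to compound 3 (0.70 log units; beyond the scatter) with the shared core and its hydroxamic acid chain unchanged. Among the compounds shown here, this is the only step available, and it shows that an exchange between two aromatic groups of equal heavy-atom count, both with no hydrogen-bond donors or acceptors, can go beyond the scatter, so those counts do not separate the two compounds. No available measurement bears on what lies behind the lower number.

The exchange alters both the substituent on the phenyl ring and its placement, so a single step cannot show which of the two accounts for the difference; a 4-methylphenyl or a 3-bromophenyl group would separate them. Also open, on these data alone, is how far this position tolerates other kinds of group, such as a 4-aminophenyl or a 4-carboxyphenyl, and whether the step would keep its size with a longer chain carrying the hydroxamic acid.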